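The source may hold more compounds than are shown below. What is called first, only, known or untested is meant among the compounds shown, and "the series" means these compounds.

Measured compounds:
compound 1, `COc1ccc2c(c1)NC(=O)CN2c1nc(OCC2CC2)nc2ccccc12`, 15.8 nM;
compound 2, `COc1ccc2c(c1)NC(=O)CN2c1nc(Nc2cccc(C#N)c2)nc2ccccc12`, 75.4 nM;
compound 3, `COc1ccc2c(c1)NC(=O)CN2c1nc(N2CCCC2)nc2ccccc12`, 45 nM.

In a functional assay on A549 cells (Homo sapiens) for inhibition, read by sulforhodamine B assay, with a stated time of 48 h (a higher number here means a weaker inhibitor of growth, a lower number a stronger inhibitor of growth), compound 1 gives the lowest number of the three. Its nearest neighbour is compound 3, a 2.8-fold higher number from compound 1 to compound 3 (0.45 log units; beyond the scatter), and the furthest is compound 2, a 4.8-fold higher number from compound 1 to compound 2 (0.68 log units; beyond the scatter). Compound 4, `CCCCNc1nc(N2CC(=O)Nc3cc(OC)ccc32)c2ccccc2n1`, differs from compound 1 in one place: butylamino in place of cyclopropylmethoxy on an aromatic carbon. The two measured steps from compound 1 bear on this change, since each also replaced the cyclopropylmethoxy group, and each gave a modestly higher number. A step of similar size and direction is therefore expected for compound 4, a 2.5-fold higher number from compound 1 to compound 4 (0.40 log units; beyond the scatter). In this assay compound 4 is estimated at 40 nM, with a range from 15 nM to 110 nM.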

Compound 4, concentration for 50% growth inhibition: 5.25 nM
For compound 4 the middle estimate is 7.6-fold (0.88 log units) above the measured one, and the stated range ends above it.
By their numbers in this assay, from the lowest: compound 4; then compound 1; then compounds 3 and 2 (each within the scatter of the next).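

At the position between two ring nitrogen atoms, both earlier replacements of cyclopropylmethoxy raised the number in this assay, yet butylamino brings a 3.0-fold lower number from compound 1 to compound 4 (0.48 log units; beyond the scatter) and so reverses the direction. It also stands apart from the other two nitrogen-linked groups, with an 8.6-fold lower number from compound 3 to compound 4 (0.93 log units; beyond the scatter) and a 14-fold lower number from compound 2 to compound 4 (1.16 log units; beyond the scatter) at the same place, so the linking nitrogen alone does not set the number. No measurement offered here gives a reason for this gain.

On these data alone, whether propylamino, hexylamino or a branched chain such as isobutylamino would keep the gain remains open. So does whether butoxy would match butylamino.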